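Lengthening an Amide Substituent on an Inactive Shared Core

The source may hold more compounds than are shown below. What is called first, only, known or untested is meant among the compounds shown, and "the series" means these compounds.

Compound 2 `COc1cc(-n2cccc2C(=O)N(C)C)ccc1Nc1ncc(Cl)c(Nc2ccccc2NS(C)(=O)=O)n1` carries a dimethylcarbamoyl group on its shared core. In a functional assay on A549 cells (Homo sapiens) for antiproliferative activity, read by MTT assay, with a stated time of 72 h (a lower number here means a stronger inhibitor, a higher number a weaker inhibitor), compound 2 gives only a limit, > 10000 nM. Compound 1 `CCN1CCN(C(=O)c2cccn2-c2ccc(Nc3ncc(Cl)c(Nc4ccccc4NS(C)(=O)=O)n3)c(OC)c2)CC1` likewise returns only a limit in this assay, > 10000 nM. For the measured compounds named here, the one measured step, a step that the two limits leave unreadable from compound 1 to compound 2, is therefore unreadable, as both values sit at the limit of > 10000 nM in this assay, at which 2 of the 2 values shown sit. Compound 3 `CCN(CC)C(=O)c1cccn1-c1ccc(Nc2ncc(Cl)c(Nc3ccccc3NS(C)(=O)=O)n2)c(OC)c1` differs from compound 2 by diethylamino in place of dimethylamino on a carbonyl carbon. No readable step bears on this change, and neither measured compound has shown activity within range. Compound 3 is therefore expected to stay at the limit, the expected step that the limit leaves unreadable from compound 2 to compound 3 meaning nothing beyond the scatter. The estimate for compound 3 is 15000 nM, between 5000 nM and 50000 nM.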

Compound 3, half-maximal inhibitory concentration: 970 nM
Compound 3: middle estimate off by 15-fold (1.19 log units), on the high side; the measured number lies below the stated range.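

With diethylamino in place of dimethylamino on a carbonyl carbon, this assay gives an at least 10-fold lower number from compound 2 to compound 3 (1.01 log units; beyond the scatter), so this position does respond to the amine on the amide, which the earlier pair could not show. Diethylamino in place of 4-ethylpiperazin-1-yl gives an at least 10-fold lower number from compound 1 to compound 3 (1.01 log units; beyond the scatter). Compound 1 and compound 2 remain limits, so the step between them cannot be read: the limit of > 10000 nM in this assay, at which 2 of the 3 values shown sit.

The compounds shown leave open whether the drop continues with a longer chain such as dipropylamino. They also leave open whether it survives in a ring amine such as pyrrolidin-1-yl.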